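The source may hold more compounds than are shown below. What is called first, only, known or untested is meant among the compounds shown, and "the series" means these compounds.

Three compounds built on a shared core were tested in a functional assay; on this read-out higher numbers stand for weaker inhibition and lower numbers for stronger inhibition. Compound 1 `CC(C)=CCOc1ccc2c(c1)OC(c1ccccc1Cl)CC2=O` gives 8020 nM. Compound 2 `CC(C)=CCOc1ccc2c(c1)OC(c1cccc(Cl)c1)CC2=O` gives 6300 nM, so that a 1.3-fold lower number from compound 1 to compound 2 (0.10 log units; within the scatter); the change here is 3-chlorophenyl in place of 2-chlorophenyl on a saturated ring carbon. Compound 3 `CC(C)=CCOc1cc(O)c2c(c1)OC(c1ccccc1Cl)CC2=O` gives 4270 nM, so that a 1.9-fold lower number from compound 1 to compound 3 (0.27 log units; within the scatter); the change here is hydroxy in place of hydrogen on an aromatic carbon. All three numbers lie within the usual scatter of one another, so no order among them can be read from these data.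

Compound 4 `CC(C)=CCOc1cc(O)c2c(c1)OC(c1cccc(Cl)c1)CC2=O` has not yet been measured in this assay. Among the compounds with values here, it differs from compound 3 by 3-chlorophenyl in place of 2-chlorophenyl on a saturated ring carbon, the same change as the one from compound 1 to compound 2, made at the same place. The two cores on which this change is made differ by hydroxy in place of hydrogen on an aromatic carbon. The step from compound 3 to compound 4 is expected to be about as small as the earlier one, an estimated 1.3-fold lower number from compound 3 to compound 4 (0.11 log units; within the scatter), because the earlier step was a 1.3-fold lower number from compound 1 to compound 2 (0.10 log units; within the scatter). Compound 4 is accordingly estimated at 3300 nM, most likely between 1500 nM and 7500 nM.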

Compound 4, half-maximal inhibitory concentration: 6060 nM
Beside the measured number, compound 4's estimate is 1.8-fold (0.26 log units) below it; the measured number falls inside the stated range.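

In this assay, 3-chlorophenyl in place of 2-chlorophenyl gives a 1.4-fold higher number from compound 3 to compound 4 (0.15 log units; within the scatter), and this step cannot be told apart from the one seen on the other core: the same change on two cores in this assay, a 1.3-fold lower number (0.10 log units; within the scatter) from compound 1 to compound 2 and a 1.4-fold higher number (0.15 log units; within the scatter) from compound 3 to compound 4, 1.8-fold (0.26 log units) apart, within the scatter of two such steps. The hydroxy change reads the same way, with a 1.0-fold lower number from compound 2 to compound 4 (0.02 log units; within the scatter) on the core carrying 3-chlorophenyl, and again the two steps cannot be told apart: the same change on two cores in this assay, a 1.9-fold lower number (0.27 log units; within the scatter) from compound 1 to compound 3 and a 1.0-fold lower number (0.02 log units; within the scatter) from compound 2 to compound 4, 1.8-fold (0.26 log units) apart, within the scatter of two such steps. Both changes therefore carry from one core to the other without any detectable difference, but every step here is itself within the scatter, so these four compounds do not show that either change has a real effect, and agreement between such small steps is weak evidence of a rule that would hold on other cores.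

As far as these compounds go, whether any change can produce a step beyond the scatter remains open. An amine or a carboxylic acid in place of the hydroxy, or a plain phenyl in place of the chlorophenyl, could answer that, and the compounds shown give no hint of the outcome.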